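The compounds below may be only part of what the source reports. "The series", "measured", "known", "first", "only" and "open" are said of these compounds alone.

Measured compounds: compound 1 `COc1ccc(C2=C(c3cc(OC)c(OC)c(OC)c3)C(=O)C(OC(C)=O)C2)cc1Cl` and compound 2 `COCOc1cc(C2=C(c3cc(OC)c(OC)c(OC)c3)C(=O)CC2O[SiH2]C(C)(C)C)ccc1OC`.

In an ADME assay on PA-1 cells (Homo sapiens) for cytotoxicity, read by MTT assay, with a stated time of 72 h (a lower number here means a stronger inhibitor, a higher number a weaker inhibitor), compound 1 gives only the assay limit of > 100 ug/mL; this is a limit, not a number, as the limit of > 100 ug/mL in this assay, at which 1 of the 2 values shown sits, records. In this assay, within the data shown here, compound 2 gives 13.5 ug/mL, the only numerical value among the two results. Compound 3 `COc1cc(C2=C(c3ccccc3)C(O[SiH2]C(C)(C)C)CC2=O)cc(OC)c1OC` is not yet measured. It differs from compound 2 by phenyl in place of 4-methoxy-3-(methoxymethoxy)phenyl on a double-bonded ring carbon. Among the measured compounds shown here, no step between measured compounds exists to calibrate this change, so the expectation rests on compound 2 alone. Compound 3 is expected to be weaker than compound 2 by a step beyond the scatter, a 3.0-fold higher number from compound 2 to compound 3 (0.47 log units; beyond the scatter), giving an estimated 40 ug/mL with a range from 10 ug/mL to 100 ug/mL.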

Compound 3, half-maximal inhibitory concentration: > 100 ug/mL
Compound 3 gave a limit, no number; the forecaster's own chance of this, stated with the estimate: 25%; middle value at least 2.5-fold (0.39 log units) from the limit.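

Phenyl in place of 4-methoxy-3-(methoxymethoxy)phenyl on a double-bonded ring carbon gives, in this assay, an at least 7.4-fold higher number from compound 2 to compound 3 (0.86 log units; beyond the scatter). Among these compounds, this is the first step measured at this position, and it shows that the position is sensitive to this change, which leaves compound 2 as the only compound with a numerical value. The reading for compound 3 is a limit, not a number: the limit of > 100 ug/mL in this assay, at which 2 of the 3 values shown sit.

Going by these compounds, how far the step extends past that limit stays open, as does whether the methoxy or the methoxymethoxy group accounts for it. A phenyl ring carrying only one of them, or a hydroxyl or an amine in that place, would separate these possibilities.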